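The source may hold more compounds than are shown below. What is called first, only, known or untested is meant among the compounds shown, and "the series" means these compounds.

Compound 1, `Cc1ccc(C2C(C#N)=C(N)N(c3ccc(S(N)(=O)=O)cc3)C3=C2C(=O)CCC3)cc1`: 30%
Compound 2, `N#CC1=C(N)N(c2ccc(S(N)(=O)=O)cc2)C2=C(C(=O)CCC2)C1c1ccc(O)cc1`: 95%

Both numbers come from a functional assay on Ehrlich cells (Mus musculus) for antiproliferative activity, read by trypan blue exclusion, with a stated time of 2 h, tested at 25 ug/mL; on this read-out lower numbers stand for a weaker effect and higher numbers for a stronger effect at the one concentration tested. Among the measured compounds shown here, compound 2 stands highest of the two; its only neighbour is compound 1, and the step of a number 65 percentage points higher from compound 1 to compound 2 (beyond the scatter) lies beyond the scatter, so the two are clearly apart. Compound 3, `N#CC1=C(N)N(c2ccc(S(N)(=O)=O)cc2)C2=C(C(=O)CCC2)C1c1ccco1`, has not yet been measured. For the measured compounds named here, its one difference from compound 2 is furan-2-yl in place of 4-hydroxyphenyl on a saturated ring carbon. Going by the values given here, no measured step changes this group in the same way, so the expectation rests on one indirect observation: the step of a number 65 percentage points higher from compound 1 to compound 2 (beyond the scatter) shows that the group at this saturated ring carbon can move the number a long way, and that the group carrying the hydroxy goes with the high number. The entering furan-2-yl carries no hydrogen-bond donor, unlike the leaving 4-hydroxyphenyl. Compound 3 is therefore expected to fall back from compound 2 by a number 40 percentage points lower from compound 2 to compound 3 (beyond the scatter), with wide uncertainty. The estimate for compound 3 in this assay is 55%, between 20% and 90%.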

Compound 3, a percentage reported as activity, at one concentration (the size of the read-out at that concentration, not a potency): 0%
Estimate against measurement, compound 3: 55 percentage points above; measured number outside the range, below it.
By their numbers in this assay, from the lowest: compound 3; then compound 1; then compound 2.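

In this assay, the group on this saturated ring carbon can do more than raise the number: furan-2-yl in place of 4-hydroxyphenyl gives a number 95 percentage points lower from compound 2 to compound 3 (beyond the scatter) and removes the whole effect. Furan-2-yl in place of 4-methylphenyl also gives a number 30 percentage points lower from compound 1 to compound 3 (beyond the scatter) in the same direction, so lacking the hydroxy does not by itself set the number, since these two hydroxy-free compounds still stand apart. Nothing measured here gives a reason for these differences.

Going by these compounds, whether the high number needs the hydroxy itself remains open, and a 4-methoxyphenyl or 4-aminophenyl group on this carbon would bear on that. A plain phenyl or a thiophen-2-yl group would help show whether the loss follows the five-membered ring or its oxygen.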